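The source may hold more compounds than are shown below. What is called first, only, known or untested is meant among the compounds shown, and "the series" means these compounds.

Among the compounds with values here, in an ADME assay (liver, Mus musculus) for metabolic stability, using microsomes (on this read-out higher numbers stand for a longer-lived compound and lower numbers for a shorter-lived compound), compound 1 (`C=CC(=O)Nc1cccc(CNc2nc(Nc3cnoc3)ncc2Cl)c1`) gives a half-life of 0.0583 h and compound 2 (`C=CC(=O)Nc1cccc(CNc2nc(Nc3cnn(C(F)F)c3)ncc2Cl)c1`) gives 0.173 h, the higher of the two numbers so far. Compound 3 (`C=CC(=O)Nc1cccc(CNc2nc(Nc3cnn(C4CCN(C(C)=O)CC4)c3)ncc2Cl)c1`) differs from compound 2 by one change, with 1-acetylpiperidin-4-yl in place of difluoromethyl on an aromatic nitrogen. Within the data shown here, only one measured step bears on this, and only loosely. It is the modest rise (a 3.0-fold higher number from compound 1 to compound 2 (0.47 log units; beyond the scatter)) seen when 1-(difluoromethyl)-1H-pyrazol-4-yl replaced 1,2-oxazol-4-yl. Among the measured compounds shown here, no measured compound carries 1-acetylpiperidin-4-yl, so the direction is poorly supported. A step no larger than that modest one is expected in this assay, most likely a slight fall that stays within the scatter (a 1.4-fold lower number from compound 2 to compound 3 (0.16 log units; within the scatter)). Compound 3 is therefore estimated at 0.12 h, with an expected range from 0.05 h to 0.3 h.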

Compound 3, half-life: 0.05 h
Compound 3: the middle estimate sits 2.4-fold (0.38 log units) above what was measured, and the stated range covers the measured number.
By their numbers in this assay, from the lowest: compounds 3 and 1 (each within the scatter of the next); then compound 2.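

In this assay, the aromatic nitrogen of the five-membered ring proves sensitive to its substituent: the change to 1-acetylpiperidin-4-yl from difluoromethyl gives a 3.5-fold lower number from compound 2 to compound 3 (0.54 log units; beyond the scatter) with the rest of the molecule held constant. The earlier step had exchanged the whole five-membered ring with its substituent, whereas this one isolates the group on that nitrogen and shows that a group bearing a six-membered non-aromatic ring can cost half-life relative to difluoromethyl. Nothing measured here gives a reason for this step.

Going by these compounds, it remains open whether the fall belongs to the piperidine ring or to its acetyl group, and a free piperidine amine or a simple methyl on the same nitrogen would help separate the two. On these data alone, whether a cyclopropyl or a longer alkyl chain at this position would behave like difluoromethyl also remains open.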